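Triazole nitrogen substituent series: from phenyl to bromophenyl acetamide

The compounds below may be only part of what the source reports. "The series", "measured", "known", "first", "only" and "open" are said of these compounds alone.

Compound 2 `CCOC(=O)C1=Cc2ccccc2OC1(OCc1cn(-c2ccccc2)nn1)C(F)(F)F` carries a phenyl on the triazole nitrogen of the shared core. In a functional assay on DU-145 cells (Homo sapiens) for inhibition, read by MTT assay, with a stated time of 24 h (on this read-out lower numbers stand for stronger inhibition and higher numbers for weaker inhibition), compound 2 gives > 150000 nM, which is a limit of the assay and not a number. Within the data shown here, its one measured neighbour, compound 1 `CCOC(=O)C1=Cc2ccccc2OC1(OCc1cn(CC(=O)Nc2ccc(C)cc2)nn1)C(F)(F)F`, bears a ((4-methylphenyl)carbamoyl)methyl at the same nitrogen. In this assay compound 1 gives > 150000 nM, again a limit of the assay. Among the measured compounds shown here, the step between them, a step that the two limits leave unreadable from compound 1 to compound 2, cannot be read, since both ends sit at the limit, and the only evidence in hand is the limit of > 150000 nM in this assay, at which 2 of the 2 values shown sit.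

Compound 3 `CCOC(=O)C1=Cc2ccccc2OC1(OCc1cn(CC(=O)Nc2ccccc2Br)nn1)C(F)(F)F` is unmeasured. Relative to compound 2 the change is ((2-bromophenyl)carbamoyl)methyl in place of phenyl on an aromatic nitrogen. For the measured compounds named here, no measured step gives a readable size for this kind of exchange; the only comparable pair, compound 1 against compound 2, shows the same limit at both ends. The expectation is therefore that the step that the limit leaves unreadable from compound 2 to compound 3 stays unreadable, with compound 3 most probably again reported as a limit in this assay. Compound 3 is estimated at 200000 nM in this assay, with an expected range from 40000 nM to 600000 nM.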

Compound 3, half-maximal inhibitory concentration: > 150000 nM
Compound 3 ended at the assay's limit; the forecaster's own chance of this, stated with the estimate: 85%; the middle value is on the limit's open side.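

Compound 3 joins compound 1 and compound 2 at the limit of this assay, so no new step among these compounds can be read: the limit of > 150000 nM in this assay, at which 3 of the 3 values shown sit.

The compounds shown leave open whether any group on the aromatic nitrogen of the shared core gives a measurable value in this assay, and how large a step between such groups would be.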